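The compounds below may be only part of what the source reports. "The series", "measured", "known", "first", "only" and "open" are said of these compounds alone.

Measured compounds and their values:

Compound 1 `COc1ccc(/C=C/C(=O)c2cc(-c3ccc(OC)c(OC)c3)n3nc(-c4ccccc4)cc3n2)cc1` gives 19300 nM in a functional assay on A549 cells (Homo sapiens) for antiproliferative activity, read by MTT assay, with a stated time of 24 h; a lower number here means a stronger inhibitor, a higher number a weaker inhibitor.
Compound 2 `COc1ccc(-c2cc(C(=O)/C=C/c3ccc(Cl)cc3)nc3cc(-c4ccccc4)nn23)cc1OC` gives 22000 nM in this assay.

Among the measured compounds shown here, compound 2 has the highest of the two numbers so far, but its nearest neighbour is compound 1, and the difference between them is a 1.1-fold higher number from compound 1 to compound 2 (0.06 log units; within the scatter), so the two compounds cannot be told apart on these data.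

Compound 3 `COc1ccc(-c2cc(/C=C/C(=O)c3ccc(C)c(C)c3)nc3cc(-c4ccccc4)nn23)cc1OC` is the next compound to be measured in this assay. Compared with compound 2, the change is 2-((3,4-dimethylphenyl)carbonyl)ethenyl in place of (2-(4-chlorophenyl)ethenyl)carbonyl on an aromatic carbon. For the measured compounds named here, the only measured step, from compound 1 to compound 2, exchanges one substituent on the outer aromatic ring and amounts to a 1.1-fold higher number from compound 1 to compound 2 (0.06 log units; within the scatter); it does not touch the way the carbonyl and the ethenyl link are arranged between the core and the outer ring, so it bears only loosely on the present change. The two measured compounds sit close together, and nothing in the data points to a shift in either direction for this new arrangement. Compound 3 is therefore expected to give about 20000 nM in this assay, within a range of 6000 nM to 65000 nM, a step of a 1.1-fold lower number from compound 2 to compound 3 (0.04 log units; within the scatter) that is expected to stay within the scatter.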

Compound 3, half-maximal inhibitory concentration: 9300 nM
For compound 3 the middle estimate is 2.2-fold (0.33 log units) above the measured one, and the stated range covers the measured number.
By their numbers in this assay, from the lowest: compound 3; then compounds 1 and 2 (each within the scatter of the next).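

Moving from the earlier pair to this arrangement at the aromatic carbon opposite the ring nitrogen gives the first difference in this assay that lies beyond the scatter: a 2.4-fold lower number from compound 2 to compound 3 (0.37 log units; beyond the scatter) when the leaving group is (2-(4-chlorophenyl)ethenyl)carbonyl, and a 2.1-fold lower number from compound 1 to compound 3 (0.32 log units; beyond the scatter) when it is (2-(4-methoxyphenyl)ethenyl)carbonyl. Both steps are modest, yet they place compound 3 lowest of the three, whereas the exchange of substituents on the outer ring in the earlier pair could not separate its two compounds. The entering 2-((3,4-dimethylphenyl)carbonyl)ethenyl group carries the same counted ring and double bonds as the groups it replaces, but no measurement offers an explanation for the lower number.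

The compounds shown do not settle whether the reversed order of carbonyl and ethenyl or the two methyl groups on the ring accounts for this step, since compound 3 differs from the others in both features at once. As far as these compounds go, it also remains open how the reversed arrangement would read with a chloro or methoxy group on its ring, or with an amine or a carboxylic acid there.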